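Shifting a Fluorine on the Aryl Ring of Compound 3

This account rests on a few compounds, and the source may have more. Where it says the series, first, only, none or still open, it means among the compounds named here.

Compound 1 `Cc1cccc(NC(=O)CN2CCC(c3ccc(O)cc3)CC2)c1` gives 70 nM in a functional assay on HEK293 cells for agonist activity at D(4) dopamine receptor (Homo sapiens), read by FLIPR; a higher number here means that more compound is needed for the effect, a lower number that less compound is needed.
Compound 2 `Cc1cccc(NC(=O)CN2CCC(c3cccc(C#N)n3)CC2)c1` gives 36 nM in this assay.
Compound 3 `Cc1cccc(NC(=O)CN2CCC(c3ccccc3F)CC2)c1` gives 1 nM in this assay.

All three share one core and differ only in the aromatic group attached to a saturated ring carbon. Compound 3 stands lowest of the three numbers: the change from compound 1 to compound 3 is a 70-fold lower number from compound 1 to compound 3 (1.85 log units; beyond the scatter), and that from compound 2 to compound 3 is a 36-fold lower number from compound 2 to compound 3 (1.56 log units; beyond the scatter), both large. The change from compound 1 to compound 2 is a 1.9-fold lower number from compound 1 to compound 2 (0.29 log units; within the scatter), so those two cannot be ordered.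

Compound 4 `Cc1cccc(NC(=O)CN2CCC(c3cccc(F)c3)CC2)c1` has not been measured. It differs from compound 3 as follows: 3-fluorophenyl in place of 2-fluorophenyl on a saturated ring carbon.

Among the measured compounds shown here, no measured step moves a fluorine from one ring position to another, so no step bears directly on this change. What the measured steps do show is that the identity of this aromatic group shifts the number strongly, as seen in a 70-fold lower number from compound 1 to compound 3 (1.85 log units; beyond the scatter) and a 36-fold lower number from compound 2 to compound 3 (1.56 log units; beyond the scatter). Since compound 3 already holds the lowest number, the step from compound 3 to compound 4 is expected to be a moderate rise, a 5.0-fold higher number from compound 3 to compound 4 (0.70 log units; beyond the scatter). In this assay compound 4 is estimated at 5 nM, with a range from 1.5 nM to 25 nM.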

Compound 4, half-maximal effective concentration: 512 nM
Estimate against measurement, compound 4: 100-fold (2.01 log units) below; the whole stated range lies below it.
By their numbers in this assay, from the lowest: compound 3; then compounds 2 and 1 (each within the scatter of the next); then compound 4.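

Swapping 2-fluorophenyl for 3-fluorophenyl keeps the same atoms and the same counts of hydrogen-bond donors and acceptors, yet in (this assay) it gives the largest step in the series (a 510-fold higher number from compound 3 to compound 4 (2.71 log units; beyond the scatter)), so where the fluorine sits on the ring can matter more than replacing the whole aromatic group did among the earlier compounds. The low number of compound 3 therefore cannot be credited to a fluorophenyl group as such, since the 3-fluorophenyl group also does worse than two quite different groups (a 14-fold higher number from compound 2 to compound 4 (1.15 log units; beyond the scatter); a 7.3-fold higher number from compound 1 to compound 4 (0.86 log units; beyond the scatter)), the second of these steps being modest. The data shown offer no measurement that explains why moving one fluorine has so large an effect.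

Going by these compounds, it remains open whether the low number depends on fluorine itself or would also appear with another group in its place, such as 2-chlorophenyl, 2-methylphenyl or 2-methoxyphenyl. Also unresolved is where 4-fluorophenyl or unsubstituted phenyl would fall relative to compound 3 and compound 4.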